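Mirroring one stereocentre in compound 2

This account rests on a few compounds, and the source may have more. Where it says the series, first, only, none or still open, it means among the compounds named here.

In a functional assay on HCT-116 cells (Homo sapiens) for inhibition, read by sulforhodamine B assay, with a stated time of 96 h (on this read-out lower numbers stand for stronger inhibition of growth and higher numbers for weaker inhibition of growth), compound 1 `CC[C@@H](Nc1nc(NCc2ccccn2)c2ncn(C(C)C)c2n1)C(C)(C)O` gives > 50000 nM, which is a limit and not a number. Within the data shown here, compound 2 `CC[C@@H](Nc1nc(NCc2ccccn2)c2ncn(C(C)C)c2n1)C(C)O` gives 18000 nM, the only true number so far. Compound 3 `CC[C@H](Nc1nc(NCc2ccccn2)c2ncn(C(C)C)c2n1)C(C)O` differs from compound 2 in one place: the two compounds have the same atoms and bonds; at least one stereo element is drawn with a configuration in one of them and without one in the other: 1 of 2 stereo elements differ; a stereocentre at a saturated chain carbon is drawn R in compound 2 and S in compound 3. Among the measured compounds shown here, the one measured step, an at least 2.7-fold lower number from compound 1 to compound 2 (0.44 log units; beyond the scatter), swaps atoms and leaves this configuration alone, so it offers no size for this change. With no guide, no step beyond the scatter is expected, and the expected change is a 1.1-fold higher number from compound 2 to compound 3 (0.05 log units; within the scatter). Compound 3 is estimated at 20000 nM, with an expected range of 8000 nM to 50000 nM.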

Compound 3, concentration for 50% growth inhibition: 10000 nM
Beside the measured number, compound 3's estimate is 2.0-fold (0.30 log units) above it; low and high end bracket the measured number.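

In this assay, mirroring this stereocentre gives a 1.8-fold lower number from compound 2 to compound 3 (0.26 log units; within the scatter), so this change of configuration does not stand out from the scatter. With the other drawn configuration, hydrogen in place of the extra methyl still comes with a lower number, an at least 5.0-fold lower number from compound 1 to compound 3 (0.69 log units; beyond the scatter), as it did in the earlier step. Compound 1's value of > 50000 nM is a limit and not a number.

On these data alone, the effect of the second stereo element remains open. So does whether an amine in place of the hydroxyl would shift the number beyond the scatter.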